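Cytotoxicity on PBMC cells across the dichloropyridine amide series

This account rests on a few compounds, and the source may have more. Where it says the series, first, only, none or still open, it means among the compounds named here.

Three members of the series have numbers in an ADME assay on PBMC cells (Homo sapiens) for cytotoxicity; on this read-out lower numbers stand for higher toxicity in this test and higher numbers for lower toxicity in this test. Compound 1 `CC(CCNC(=O)c1c(Cl)cncc1Cl)N1CCC(C(Oc2ccncc2)c2ccc(Br)cc2)CC1` gives 31200 nM. Compound 2 `Cc1ccnc(OC(c2ccc(C(F)(F)F)cc2)C2CCN(C(C)CCNC(=O)c3c(Cl)cncc3Cl)CC2)c1` gives 33600 nM, the highest of the two numbers measured; its nearest neighbour is compound 1, and the gap between them is within the scatter, so the two cannot be ordered. Compound 3 `CC(CCNC(=O)c1c(Cl)cncc1Cl)N1CCC(C(Oc2cccc(Cl)n2)c2ccc(S(C)(=O)=O)cc2)CC1` sits at the limit of > 29500 nM in this assay, at which 1 of the 3 values shown sits, which is a limit of the assay and not a number; for compound 3 the value reads > 29500 nM.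

Compound 4 `CC(CCNC(=O)c1c(Cl)cncc1Cl)N1CCC(C(Oc2ccc(C(F)(F)F)cc2)c2ccc(C(F)(F)F)cc2)CC1` has not yet been measured in this assay. It differs from compound 2 in one place: 4-(trifluoromethyl)phenyl in place of 4-methylpyridin-2-yl on an oxygen on a saturated carbon. Among the compounds with values here, no step between two measured compounds has been worked out, so there is nothing in the data that links a change of this kind to a shift in the read-out. What the three measured compounds show is a narrow band of numbers and limits in this assay, with no measured step beyond the scatter anywhere in the series.

On that basis the step from compound 2 to compound 4 is expected to be small, a 1.2-fold lower number from compound 2 to compound 4 (0.08 log units; within the scatter), with no direction beyond the scatter. Compound 4 is estimated at 28000 nM, within a range of 14000 nM to 56000 nM.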

Compound 4, half-maximal cytotoxic concentration: 3100 nM
The estimate for compound 4 lay 9.0-fold (0.96 log units) above the measured number, and the stated range ends above it.
By their numbers in this assay, from the lowest: compound 4; then compounds 1 and 2 (each within the scatter of the next).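

Within the data shown here, at the place on an oxygen on a saturated carbon, 4-(trifluoromethyl)phenyl in place of 4-methylpyridin-2-yl gives the first measured step beyond the scatter in this assay: an 11-fold lower number from compound 2 to compound 4 (1.03 log units; beyond the scatter). The read-out in this test is therefore not fixed across the series, and for this pair, what sits on that oxygen separates a higher number from a lower one, the lower number standing for higher toxicity in this test. The change removes the ring nitrogen and the methyl group and brings in a trifluoromethyl group in one step, and nothing measured here identifies the cause of the shift.

Which part of the change carries the step stays open, and 4-methylphenyl or 4-(trifluoromethyl)pyridin-2-yl on the same oxygen would separate the loss of the ring nitrogen from the arrival of the trifluoromethyl group. Also open is whether the step holds with another group in place of the 4-(trifluoromethyl)phenyl on the saturated carbon, such as a 4-cyanophenyl, since the compounds shown give only this one pair.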